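Swapping an Amine for a Cyclohexyloxy Group on the Carbonyl

This account rests on a few compounds, and the source may have more. Where it says the series, first, only, none or still open, it means among the compounds named here.

Compound 1 `CC1=C(C(=O)OCc2ccccc2)C(c2ccoc2)NC(=O)N1`: 41%
Compound 2 `CC1=C(C(=O)NC(C)C)C(c2ccoc2)NC(=O)N1`: 1%

In an assay on membranes from CHO cells for displacement of a labelled ligand from adenosine receptor A1 (Homo sapiens), read by scintillation counting, with a stated time of 60 min, tested at 1 uM (a lower number here means less inhibition, a higher number more inhibition at the concentration tested (going by the name of the read-out)), compound 1 gives 41%, while compound 2 gives 1%, the lower of the two numbers and far below compound 1, well beyond the scatter. Compound 3 `CC1=C(C(=O)OC2CCCCC2)C(c2ccoc2)NC(=O)N1` carries cyclohexyloxy in place of isopropylamino on a carbonyl carbon. Compound 1 also bears an oxygen-linked group on that carbonyl carbon and gives 41%, so a move back toward such a group is expected to raise inhibition: an upward step a number 29 percentage points higher from compound 2 to compound 3 (beyond the scatter) beyond the scatter. Compound 3 is expected to give about 30%, plausibly between 5% and 60%.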

Compound 3, a percentage reported as inhibition, at one concentration (the size of the read-out at that concentration, not a potency): 15%
For compound 3 the middle estimate is 15 percentage points above the measured one, and the stated range covers the measured number.
By their numbers in this assay, from the lowest: compound 2; then compound 3; then compound 1.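

In this assay, cyclohexyloxy in place of isopropylamino on the carbonyl carbon gives a number 14 percentage points higher from compound 2 to compound 3 (beyond the scatter), so this oxygen-linked group keeps some inhibition that the isopropylamino compound lacks. Cyclohexyl in place of benzyl on the oxygen gives a number 26 percentage points lower from compound 1 to compound 3 (beyond the scatter), so the group carried by that oxygen also matters, not just the oxygen link itself. Nothing available explains either step. From the compounds shown here alone, how an ethoxy group or a carboxylic acid at this carbonyl carbon would compare remains open.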